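Urea aryl swap on a benzothiazole ether series

The source may hold more compounds than are shown below. What is called first, only, known or untested is meant among the compounds shown, and "the series" means these compounds.

Measured compounds in a functional assay on HCT-116 cells (Homo sapiens) for inhibition, read by MTT assay, with a stated time of 2 days, tested at 10 uM; on this read-out lower numbers stand for less inhibition of growth and higher numbers for more inhibition of growth at the one concentration tested:
compound 1 `CNC(=O)c1cc(Oc2ccc3nc(NC(=O)c4ccc(Cl)cc4)sc3c2)ccn1` gives 27.5%
compound 2 `CNC(=O)c1cc(Oc2ccc3nc(NC(=O)c4cc(Cl)cc(Cl)c4)sc3c2)ccn1` gives 13.4%
compound 3 `CNC(=O)c1cc(Oc2ccc3nc(NC(=O)Nc4ccc(F)cc4)sc3c2)ccn1` gives 12.2%

Compound 3 holds the lowest of the three numbers in this assay. Its nearest neighbour is compound 2, and the difference a number 1.2 percentage points lower from compound 2 to compound 3 (within the scatter) is within the scatter, so no order between them is claimed. Compound 1 stands apart, with the step of a number 15.3 percentage points lower from compound 1 to compound 3 (beyond the scatter) beyond the scatter.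

Compound 4 `CNC(=O)c1cc(Oc2ccc3nc(NC(=O)Nc4ccc(Cl)cc4Cl)sc3c2)ccn1` differs from compound 3 in one place: 2,4-dichlorophenyl in place of 4-fluorophenyl on an amide-type nitrogen. Among the compounds with values here, no measured pair changes the aryl group on this urea nitrogen. The steps that do touch the aryl part, a number 14.1 percentage points lower from compound 1 to compound 2 (beyond the scatter) on the carbonyl-side phenyl and a number 15.3 percentage points lower from compound 1 to compound 3 (beyond the scatter) which also exchanges the amide for a urea, were both modest and downward. With compound 3 already near the bottom of the range, little further movement is expected. The step of a number 1.8 percentage points higher from compound 3 to compound 4 (within the scatter) is therefore estimated to stay within the scatter, and compound 4 is expected to give 14%, with a range from 2% to 34%.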

Compound 4, percent growth inhibition at one concentration: 32.2%
The estimate for compound 4 lay 18.2 percentage points below the measured number; the range from low to high includes it.
By their numbers in this assay, from the lowest: compounds 3 and 2 (each within the scatter of the next); then compounds 1 and 4 (each within the scatter of the next).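

In this assay the aryl group on this urea nitrogen proves able to move the number, and the only step shown at this place, a number 20 percentage points higher from compound 3 to compound 4 (beyond the scatter), runs upward, whereas the earlier aryl steps ran downward. The urea linkage alone does not hold the number low: the step of a number 18.8 percentage points higher from compound 2 to compound 4 (beyond the scatter) is also beyond the scatter, while the step of a number 4.7 percentage points higher from compound 1 to compound 4 (within the scatter) allows no order between that amide and this urea. No measurement shown bears on why the number rose.

On these data alone, the change swaps fluorine for two chlorines at once, so what each chlorine contributes stays open. As far as these compounds go, how the urea would respond to a 4-chlorophenyl group, or to an aminophenyl or carboxyphenyl group, on this nitrogen also remains unknown.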